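Series notes: chloro for cyano on the shared core

The source may report more compounds than this note shows. Statements on the series, on what has been measured and on what is new or still open speak of the compounds shown alone.

Compound 1 `N#Cc1c(N2CCC(c3ccccc3)CC2)ccn2c(CC(F)(F)F)nnc12` stands highest of the three numbers in a functional assay on CHO cells for positive allosteric modulation of metabotropic glutamate receptor 2 (Homo sapiens), read by GTPgammaS binding, with a stated time of 30 min (on this read-out lower numbers stand for smaller maximal responses and higher numbers for larger maximal responses), giving 277%. Compound 2 `CC(C)(C)c1nnc2c(C#N)c(N3CCC(c4ccccc4)CC3)ccn12` gives 207%, and compound 3 `N#Cc1c(N2CCC(c3ccccc3)CC2)ccn2c(CN3CCCC3)nnc12` gives 240%. Compound 4 `FC(F)(F)Cc1nnc2c(Cl)c(N3CCC(c4ccccc4)CC3)ccn12` differs from compound 1 in a single place: chloro in place of cyano on an aromatic carbon. The measured steps all concern the other substituent of the core: a number 70 percentage points lower from compound 1 to compound 2 (beyond the scatter), a number 37 percentage points lower from compound 1 to compound 3 (beyond the scatter) and a number 33 percentage points higher from compound 2 to compound 3 (beyond the scatter). For the measured compounds named here, none of them alters the cyano group, so no measured step bears directly on this change, and its direction in this assay is open. Lacking a guide, the number for compound 4 is expected to lie near that of compound 1. Compound 4 is estimated at 240%, between 150% and 320%. The expected step is a number 37 percentage points lower from compound 1 to compound 4 (beyond the scatter).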

Compound 4, largest response reached (Emax), in percent of the reference or control that the assay uses: 300%
Compound 4: middle estimate off by 60 percentage points, on the low side; measured number inside the range.
By their numbers in this assay, from the lowest: compound 2; then compound 3; then compound 1; then compound 4.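

In this assay, chloro in place of cyano on the aromatic carbon reads as a number 23 percentage points higher from compound 1 to compound 4 (beyond the scatter) with 2,2,2-trifluoroethyl held constant, so a large maximal response on this core does not depend on the nitrile. This is the only step shown at this position, as the other steps all concern the other substituent. No measured evidence accounts for the direction of this change.

On these data alone, whether chloro gives a similar step alongside tert-butyl or (pyrrolidin-1-yl)methyl remains open. As far as these compounds go, how methyl, methoxy or bromo would read at this aromatic carbon also remains open.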